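The source may report more compounds than this note shows. Statements on the series, on what has been measured and on what is new or still open speak of the compounds shown alone.

The measured compounds are:
Compound 1, `Cc1c(Cc2ccccc2)c(=O)oc2cc(OCC(O)CNCC3CC3)ccc12`, which in an ADME assay on A549 cells (Homo sapiens) for cytotoxicity, read by CellTiter-Glo (on this read-out lower numbers stand for higher toxicity in this test and higher numbers for lower toxicity in this test), gives > 100000 nM, a limit of the assay.
Compound 2, `Cc1c(Cc2ccccc2)c(=O)oc2cc(OCC(O)CNCc3ccccc3)ccc12`, which gives > 100000 nM in this assay, also a limit.
Compound 3, `Cc1c(Cc2ccccc2)c(=O)oc2cc(OCC(O)CNCc3cccs3)ccc12`, which gives 87300 nM in this assay.

Compound 1 thus stands at the limit of > 100000 nM in this assay, at which 2 of the 3 values shown sit. The step that the two limits leave unreadable from compound 1 to compound 2 cannot be read, while an at least 1.1-fold lower number from compound 1 to compound 3 (0.05 log units; that floor lies within the scatter) and an at least 1.1-fold lower number from compound 2 to compound 3 (0.05 log units; that floor lies within the scatter) are small. The unmeasured compound 4, `Cc1c(Cc2ccccc2)c(=O)oc2cc(OCC(O)CNc3nc4ccccc4[nH]3)ccc12`, differs from compound 1 by 1H-benzimidazol-2-yl in place of cyclopropylmethyl on an amine nitrogen. Among the measured compounds shown here, no measured step alters the amine nitrogen in this way; all three exchange the group on the saturated chain carbon, and none shifted the number beyond the scatter. Compound 4 is therefore expected to remain near the limit, with an at least 1.1-fold lower number from compound 1 to compound 4 (0.04 log units; that floor lies within the scatter) expected to be no step beyond the scatter. The estimate for compound 4 is 90000 nM, expected between 30000 nM and 200000 nM.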

Compound 4, half-maximal cytotoxic concentration: > 100000 nM
Compound 4 was reported as a limit; the forecaster's own chance of this, stated with the estimate: 50%; middle value at least 1.1-fold (0.04 log units) from the limit.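

Among the compounds shown here, compound 4 shows that the amine nitrogen tolerates 1H-benzimidazol-2-yl directly in place of the groups carried by the earlier compounds, without the number in this assay leaving the top of the range: the limit of > 100000 nM in this assay, at which 3 of the 4 values shown sit. The only readable step is an at least 1.1-fold higher number from compound 3 to compound 4 (0.05 log units; that floor lies within the scatter), and the steps from compound 1 and compound 2 cannot be read, as both ends are limits.

As far as these compounds go, how far the true value of compound 4 lies past its limit stays open. So does whether an acetyl group or a longer chain on this amine nitrogen would give a number clearly lower.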